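Phenyl Carbamate Selenocyanate: Expected Growth Inhibition

The source may report more compounds than this note shows. Statements on the series, on what has been measured and on what is new or still open speak of the compounds shown alone.

Measured so far:
Compound 1, `CCCCCCOC(=O)Nc1ccc([Se]C#N)cc1`: 4600 nM
Compound 2, `N#C[Se]c1ccc(NC(=O)OCc2ccc([N+](=O)[O-])cc2)cc1`: 6000 nM
Compound 3, `CCCCOC(=O)Nc1ccc([Se][Se]c2ccc(NC(=O)OCCCC)cc2)cc1`: 7200 nM

These three compounds were tested in an ADME assay on 184B5 cells (Homo sapiens) for cytotoxicity, read by MTT assay, with a stated time of 72 h; a lower number here means a stronger inhibitor of growth, a higher number a weaker inhibitor of growth. Compound 1 has the lowest number of the three, but its two neighbours sit close by: compound 2 lies within the scatter of compound 1, and so does compound 3. The three numbers therefore show no separation that can be trusted, and none of the compounds can be called the strongest or weakest inhibitor.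

Compound 4, `N#C[Se]c1ccc(NC(=O)Oc2ccccc2)cc1`, has not yet been measured in this assay. It differs from compound 1 in one place: phenyl in place of hexyl on an oxygen next to a carbonyl group. For the measured compounds named here, no measured pair shows this kind of change, so there is no direct precedent for its size. Since the three measured compounds, which differ in the group on the carbamate oxygen and in the selenium-bearing part, all land within the scatter of each other, the expectation for the step from compound 1 to compound 4 is a change of no more than the scatter, in no particular direction, giving a 1.2-fold higher number from compound 1 to compound 4 (0.08 log units; within the scatter). On that basis compound 4 is estimated at 5500 nM in this assay, with a plausible range from 2500 nM to 12000 nM.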

Compound 4, concentration for 50% growth inhibition: 400 nM
Estimate against measurement, compound 4: 14-fold (1.14 log units) above, outside the stated range (below it).
By their numbers in this assay, from the lowest: compound 4; then compounds 1, 2 and 3 (each within the scatter of the next).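

In this assay, the group on an oxygen next to a carbonyl group proves able to move the number strongly: phenyl in place of hexyl gives a 12-fold lower number from compound 1 to compound 4 (1.06 log units; beyond the scatter), a step well beyond the scatter. The earlier compounds shown here lay within the scatter of one another and gave no sign of such a step, while here the two groups have the same count of heavy atoms and differ in being an aromatic ring or an open chain. Nothing shown here accounts for the size of this step.

On these data alone, whether any ring at this position would do the same, or only an aromatic one, stays open, and a cyclohexyl group on the same oxygen would test that. A pyridyl ring would show whether the ring must be of carbon only.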